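The compounds below may be only part of what the source reports. "The series", "measured", "known", "first", "only" and "open" are said of these compounds alone.

In a functional assay on SW480 cells (Homo sapiens) for inhibition, read by luminescence and resazurin assay, with a stated time of 3 days (a lower number here means a stronger inhibitor, a higher number a weaker inhibitor), compound 2 `CN1CCN(c2nc(NCc3ccc(NC(=O)c4ccc(F)cc4)cc3)c3ccccc3n2)CC1` gives 2500 nM, compound 1 `CCCNc1nc(NCc2ccc(NC(=O)c3ccc(F)cc3)cc2)c2ccccc2n1` gives 2000 nM and compound 3 `CNc1nc(NCc2ccc(NC(=O)c3ccc(F)cc3)cc2)c2ccccc2n1` gives 2000 nM. Compound 2 therefore sits level with both: a 1.3-fold higher number from compound 1 to compound 2 (0.10 log units; within the scatter) and a 1.3-fold lower number from compound 2 to compound 3 (0.10 log units; within the scatter). Compound 4 `Cc1ccc(S(=O)(=O)Nc2ccc(CNc3nc(N4CCN(C)CC4)nc4ccccc34)cc2)cc1` keeps the 4-methylpiperazin-1-yl group of compound 2 and changes a nitrogen on an aromatic ring: (4-methylphenyl)sulfonyl in place of (4-fluorophenyl)carbonyl on a nitrogen on an aromatic ring. Going by the values given here, no measured step touches this place. The three steps only exchange propylamino, methylamino and 4-methylpiperazin-1-yl, and no change at the digits printed from compound 1 to compound 3 (within the scatter) is equally flat. They give no direction for the new change, so no step beyond the scatter is expected, though with wide uncertainty. The estimated step is a 1.2-fold higher number from compound 2 to compound 4 (0.08 log units; within the scatter). For compound 4 the expected value is 3000 nM, with an estimated range of 1000 nM to 10000 nM.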

Compound 4, half-maximal inhibitory concentration: > 20000 nM
Compound 4 ended at the assay's limit; the forecaster's own chance of this, stated with the estimate: 10%; middle value at least 6.6-fold (0.82 log units) from the limit.
By their numbers in this assay, from the lowest: compounds 1, 3 and 2 (each within the scatter of the next). At a limit, above all of these: compound 4.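

Unlike the exchanges of propylamino, methylamino and 4-methylpiperazin-1-yl, the group on this nitrogen on an aromatic ring is not silent in this assay: (4-methylphenyl)sulfonyl in place of (4-fluorophenyl)carbonyl is the only single change shown that goes beyond the scatter (an at least 8.0-fold higher number from compound 2 to compound 4 (0.90 log units; beyond the scatter)). From the compounds shown here alone, compound 4 (> 20000 nM) stands at a limit of the assay, not at a number, so the true size of this step stays unknown.

Sulfonyl and the ring's methyl replace carbonyl and fluorine together, so neither can be held responsible alone. A (4-fluorophenyl)sulfonyl or (4-methylphenyl)carbonyl group on the same nitrogen would separate the two.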